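The source may report more compounds than this note shows. Statements on the series, on what has been measured and on what is new or still open speak of the compounds shown alone.

Compound 1, `Cc1ccc2[nH]c(=O)c(/C=N/c3ccccc3O)cc2c1`, in a functional assay, read by spectrophotometry, with a stated time of 3 min (a higher number here means a weaker inhibitor, a lower number a stronger inhibitor), gives 8240 nM.
Compound 2, `Cc1ccc2[nH]c(=O)c(/C=N/Nc3ccc([N+](=O)[O-])cc3[N+](=O)[O-])cc2c1`, in this assay gives 144000 nM.
Compound 3, `O=c1[nH]c2ccccc2cc1/C=N/c1ccccc1O`, in this assay gives 11700 nM.

Compound 1 and compound 3 share a core and differ in one place: hydrogen in place of methyl on an aromatic carbon. That change made a step of a 1.4-fold higher number from compound 1 to compound 3 (0.15 log units; within the scatter), so the two compounds cannot be told apart by this measurement alone. Compound 2 is built on a different core, and the difference between the two cores is not broken down here. Its number is the highest of the three, which makes compound 2 the weakest inhibitor among the measured compounds, since its gaps to compound 1 and to compound 3 both lie beyond the scatter.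

Compound 4, `O=c1[nH]c2ccccc2cc1/C=N/Nc1ccc([N+](=O)[O-])cc1[N+](=O)[O-]`, has not yet been measured. It differs from compound 2 by hydrogen in place of methyl on an aromatic carbon. Among the measured compounds shown here, this is the same change, at the same kind of place, as the one from compound 1 to compound 3. Because that earlier step was a 1.4-fold higher number from compound 1 to compound 3 (0.15 log units; within the scatter), the expectation is that removing the methyl from compound 2 will likewise move the number little, and the estimated step from compound 2 to compound 4 is a 1.3-fold higher number from compound 2 to compound 4 (0.12 log units; within the scatter). Compound 4 is therefore expected to come out near 190000 nM in this assay, with a plausible range estimated from 70000 nM to 500000 nM. A number this high sits close to the edge of what the measurement can resolve, so the outcome may be reported only as a limit.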

Compound 4, half-maximal inhibitory concentration: 142000 nM
For compound 4 the middle estimate is 1.3-fold (0.13 log units) above the measured one; the range from low to high includes it.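

Taking the methyl off the core of compound 2 and putting hydrogen in its place gives a step of a 1.0-fold lower number from compound 2 to compound 4 (0.01 log units; within the scatter), so this assay does not separate this pair. Set beside the earlier step, the same change reads alike on the two cores: the same change on two cores in this assay, a 1.4-fold higher number (0.15 log units; within the scatter) from compound 1 to compound 3 and a 1.0-fold lower number (0.01 log units; within the scatter) from compound 2 to compound 4, 1.4-fold (0.16 log units) apart, within the scatter of two such steps This shows that, for these two pairs in this one assay, swapping methyl for hydrogen at this aromatic carbon gave no step that could be read, and that the result carried from one core to the other; it does not show that the methyl has no effect at all, since an effect smaller than the scatter would go unseen, and two pairs say nothing about any further core.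

The compounds shown hold only methyl or hydrogen at this place, so they leave open how a chlorine atom, a methoxy group or an amine there would read in this assay. On these data alone, the two nitro groups on the side chain of compound 2 and compound 4 also never change one at a time, so what a single nitro group, or a carboxylic acid in its place, would give stays open.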